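Thiosemicarbazone-type series: triazolyl for pyrimidinyl on sulfur

The source may hold more compounds than are shown below. What is called first, only, known or untested is meant among the compounds shown, and "the series" means these compounds.

Measured compounds:
compound 1 `COc1ccc(-c2cs/c(=N/NC(=O)CSc3nnnn3C)n2-c2ccccc2)cc1` 45 ug/mL
compound 2 `Cn1cnnc1SCC(=O)N/N=c1/scc(-c2ccc(Cl)cc2)n1-c1ccccc1` 51.7 ug/mL
compound 3 `COc1ccc(-c2cs/c(=N/NC(=O)CSc3ncccn3)n2-c2ccccc2)cc1` 450 ug/mL

In an ADME assay on NIH3T3 cells (Mus musculus) for cytotoxicity, read by MTT assay, with a stated time of 24 h (a higher number here means a weaker inhibitor, a lower number a stronger inhibitor), compound 3 gives the highest number of the three, clearly apart from compound 2 and from compound 1. The step to compound 4 `COc1ccc(-c2cs/c(=N/NC(=O)CSc3nncn3C)n2-c2ccccc2)cc1` is 4-methyl-4H-1,2,4-triazol-3-yl in place of pyrimidin-2-yl on a sulfur. For the measured compounds named here, the one measured step at this position, a 10-fold higher number from compound 1 to compound 3 (1.00 log units; beyond the scatter), shows that the pyrimidin-2-yl group sits well above the other sulfur substituents here. Compound 2 carries the same 4-methyl-4H-1,2,4-triazol-3-yl group as compound 4, differing elsewhere, and in this assay compound 2 gives 51.7 ug/mL. Removing the pyrimidin-2-yl group is therefore expected to bring the number back down, with an 8.2-fold lower number from compound 3 to compound 4 (0.91 log units; beyond the scatter) estimated. For compound 4 the expected value is 55 ug/mL, within 25 ug/mL to 120 ug/mL.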

Compound 4, half-maximal inhibitory concentration: 167 ug/mL
The estimate for compound 4 lay 3.0-fold (0.48 log units) below the measured number; the measured number lies above the stated range.
By their numbers in this assay, from the lowest: compounds 1 and 2 (each within the scatter of the next); then compound 4; then compound 3.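

In this assay the sulfur substituent gives a graded result, with a 2.7-fold lower number from compound 3 to compound 4 (0.43 log units; beyond the scatter) and also a 3.7-fold higher number from compound 1 to compound 4 (0.57 log units; beyond the scatter) so the 4-methyl-4H-1,2,4-triazol-3-yl group matches neither pyrimidin-2-yl nor 1-methyl-1H-tetrazol-5-yl. The aromatic substituent also counts: methoxy in place of chloro gives a 3.2-fold higher number from compound 2 to compound 4 (0.51 log units; beyond the scatter) so compound 2 does not stand in for compound 4. Going by these compounds, whether that methoxy and chloro step holds with other sulfur substituents remains open, as does the outcome with an amine or a carboxylic acid on the sulfur-bound ring. No measurement here bears on why these groups differ.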